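The source may report more compounds than this note shows. Statements on the series, on what has been measured and on what is new or still open speak of the compounds shown alone.

Working notes on the series, read in a functional assay on MCF7 cells (Homo sapiens) for inhibition, read by CCK-8 assay, with a stated time of 48 h; a lower number here means a stronger inhibitor of growth, a higher number a weaker inhibitor of growth.

Compound 1, `CCN1CCN(c2ccc(Nc3ncc(Cl)c(Nc4ccccc4C)n3)nc2)CC1`, returns only a limit of the assay in this assay, > 100000 nM, a case of the limit of > 100000 nM in this assay, at which 1 of the 3 values shown sits. Compound 2, `Cc1ccccc1Nc1nc(Nc2ccc(N3CCN(C)CC3)cc2)ncc1Cl`, gives 20600 nM in this assay. Compound 3, `CN1CCN(c2ccc(Nc3ncc(Cl)c(NCc4ccc(C(F)(F)F)cc4)n3)nc2)CC1`, gives 28400 nM in this assay. Among the two numeric values shown, compound 3 holds the higher figure, though its gap to compound 2 is within the scatter, so no order between the two can be read.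

The step under consideration leads from compound 3 to compound 4, `CCc1ccc(Nc2nc(Nc3ccc(N4CCN(C)CC4)cn3)ncc2Cl)cc1`, the change being (4-ethylphenyl in place of 4-(trifluoromethyl)benzyl on a nitrogen on an aromatic ring). Among the compounds with values here, no measured pair in the set isolates this change, so there is no direct precedent for it. The remaining data point, compound 1, only sets a limit. On this basis the expectation is for a step from compound 3 to compound 4 of about a 1.1-fold higher number from compound 3 to compound 4 (0.02 log units; within the scatter), that is, no movement beyond the scatter. Compound 4 is accordingly estimated at 30000 nM in this assay, with a range from 8000 nM to 100000 nM.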

Compound 4, concentration for 50% growth inhibition: 8230 nM
Compound 4: the middle estimate sits 3.6-fold (0.56 log units) above what was measured, and the stated range covers the measured number.
By their numbers in this assay, from the lowest: compound 4; then compounds 2 and 3 (each within the scatter of the next). At a limit, above all of these: compound 1.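

In this assay, within the data shown here, 4-ethylphenyl in place of 4-(trifluoromethyl)benzyl on a nitrogen on an aromatic ring gives a 3.5-fold lower number from compound 3 to compound 4 (0.54 log units; beyond the scatter), the one step in the set that isolates a single change. Among these compounds, the earlier compounds offered no such pair, so this is the first sign that growth inhibition responds to the group at this place, though the size of the step is modest. Nothing measured here gives a cause for the step.

The change removes the benzyl carbon and exchanges trifluoromethyl for ethyl at once, so the compounds shown cannot separate the two contributions. Also open, as far as these compounds go, is how this place would respond to an unsubstituted phenyl, a longer alkyl chain on the ring, or a ring bearing an amine or a carboxylic acid.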